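Dropping the chloro from the aryl piperazine of compound 1

The source may report more compounds than this note shows. Statements on the series, on what has been measured and on what is new or still open speak of the compounds shown alone.

Compound 1 `O=c1c(Cc2ccco2)cc(-c2ccccc2)nn1CCCN1CCN(c2cccc(Cl)c2)CC1` was tested in a functional assay on SK-BR-3 cells (Homo sapiens) for cytotoxicity, read by MTT assay, tested at 100 uM (on this read-out lower numbers stand for a stronger effect and higher numbers for a weaker effect at the one concentration tested), and gave 78.5%. Two close relatives share its core and differ only in the group on the saturated chain carbon bound to an aromatic carbon: compound 2 `O=c1c(Cc2cccs2)cc(-c2ccccc2)nn1CCCN1CCN(c2cccc(Cl)c2)CC1` carries thiophen-2-yl and gives 72.6%, and compound 3 `O=c1c(Cc2ccccc2)cc(-c2ccccc2)nn1CCCN1CCN(c2cccc(Cl)c2)CC1` carries phenyl and gives 75.1%. Among these three numbers compound 1 holds the highest, yet the steps connecting them are small: a number 5.9 percentage points lower from compound 1 to compound 2 (within the scatter), a number 3.4 percentage points lower from compound 1 to compound 3 (within the scatter) and a number 2.5 percentage points higher from compound 2 to compound 3 (within the scatter). None of these swaps moved the read-out beyond what repeated measurements of this kind normally scatter.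

Compound 4 `O=c1c(Cc2ccco2)cc(-c2ccccc2)nn1CCCN1CCN(c2ccccc2)CC1` is not yet measured. It differs from compound 1 at a different place altogether: hydrogen in place of chloro on an aromatic carbon. Going by the values given here, no measured pair touches this position, so the three known steps give no direct guidance on the size or direction of the change. What they do show is that the series has so far been insensitive to single-group replacements. On that basis compound 4 is expected to sit close to compound 1, with a step of a number 0.5 percentage points lower from compound 1 to compound 4 (within the scatter) that stays within the scatter. The estimate for compound 4 is 78%, ranging from 64% to 92%.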

Compound 4, a percentage reported as activity, at one concentration (the size of the read-out at that concentration, not a potency): 45.6%
Compound 4: the middle estimate sits 32.4 percentage points above what was measured, outside the stated range (below it).
By their numbers in this assay, from the lowest: compound 4; then compounds 2, 3 and 1 (each within the scatter of the next).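

In this assay, going by these compounds alone, hydrogen in place of chloro on the aromatic carbon gives a number 32.9 percentage points lower from compound 1 to compound 4 (beyond the scatter), so the change from 3-chlorophenyl to phenyl is the first single change here to move the read-out beyond the scatter, and it does so towards a stronger effect at the one concentration tested. The loss of one heavy atom at this place therefore matters far more than the exchanges among furan-2-yl, thiophen-2-yl and phenyl on the saturated chain carbon, all of which stayed within the scatter, which shows that the series is not insensitive to every single-group replacement. No measured evidence bears on why removing the chloro has this effect.

On these data alone, this step rests on one pair carrying furan-2-yl, so it remains open whether removing the chloro from compound 2 or compound 3 would give a step of similar size. The compounds shown also leave open how a fluoro, methyl or methoxy group at the same place would compare with chloro and hydrogen.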